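Longer acyl chain on a thiadiazole-linked sugar: compound 4

The source may report more compounds than this note shows. Statements on the series, on what has been measured and on what is new or still open speak of the compounds shown alone.

Measured so far in a functional assay on MDA-MB-231 cells (Homo sapiens) for cytotoxicity, read by MTT assay, with a stated time of 24 h; on this read-out lower numbers stand for stronger inhibition and higher numbers for weaker inhibition:
compound 1 `CCCCCCCC/C=C\CCCCCCCC(=O)Nc1nnc(S[C@@H]2O[C@H](COC(C)=O)[C@H](OC(C)=O)[C@H](OC(C)=O)[C@H]2OC(C)=O)s1` gives 23600 nM
compound 2 `CCCCCCCCCCCC(=O)Nc1nnc(S[C@@H]2O[C@H](CO)[C@H](O)[C@H](O)[C@H]2O)s1` gives 32000 nM
compound 3 `CCCCCCCC(=O)Nc1nnc(S[C@@H]2O[C@H](CO)[C@H](O)[C@H](O)[C@H]2O)s1` gives 30800 nM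

Compound 3 holds the second highest of the three numbers, within the scatter of both compound 2 and compound 1, so the three cannot be set in order. Compound 4 `CCCCCCCCCCCCCC(=O)Nc1nnc(S[C@@H]2O[C@H](CO)[C@H](O)[C@H](O)[C@H]2O)s1` differs from compound 3 by hexyl in place of hydrogen on a saturated chain carbon, seven bonds along the chain from a carbonyl carbon. Going by the values given here, the one comparable step, a 1.0-fold lower number from compound 2 to compound 3 (0.02 log units; within the scatter), changed the same chain carbon and moved the number not at all beyond the scatter. Compound 4 is therefore expected to show a step of a 1.1-fold lower number from compound 3 to compound 4 (0.04 log units; within the scatter), meaning no change beyond the scatter. Compound 4 is estimated at 28000 nM, with a range from 14000 nM to 56000 nM.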

Compound 4, half-maximal inhibitory concentration: 33300 nM
The estimate for compound 4 lay 1.2-fold (0.08 log units) below the measured number, and the stated range covers the measured number.
By their numbers in this assay, from the lowest: compounds 1, 3, 2 and 4 (each within the scatter of the next).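

In this assay, hexyl in place of hydrogen on this chain carbon gives a 1.1-fold higher number from compound 3 to compound 4 (0.03 log units; within the scatter), and ethyl in place of hydrogen further out on the chain gives a 1.0-fold higher number from compound 2 to compound 4 (0.02 log units; within the scatter). Going by these compounds alone, earlier only one step at this carbon could be read; now three saturated chain lengths sit within the scatter of one another, so lengthening the chain by these amounts leaves the number unmoved. No available evidence offers an explanation.

Open, from the compounds shown here alone, is whether a carboxylic acid or an amine at the chain end would move the number. Going by these compounds, whether a much longer chain would do so also remains unknown.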